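Aryl pyrazole isomers in a cycloheptyl urea series

A few compounds are considered here, and "the series" means these few. Any claim that something is new, unique, unknown or untested is made for them only; others in the source may bear on it.

Compound 1 `Cc1cc(C)c(NC(=O)N(Cc2ccc(-c3cc[nH]n3)cc2)C2CCCCCC2)c(C)c1` and compound 3 `Cc1cc(C)c(NC(=O)N(Cc2ccc(-c3cn[nH]c3)cc2)C2CCCCCC2)c(C)c1` share one core and differ as follows: 1H-pyrazol-4-yl in place of 1H-pyrazol-3-yl on an aromatic carbon. Compound 1 in a functional assay on a cell-free system (plasma) with sterol O-acyltransferase, Soat (Rattus norvegicus) as the target (on this read-out lower numbers stand for an effect already at smaller amounts and higher numbers for an effect only at larger amounts of compound), gives only a limit, > 1 mg/kg. Compound 3 in this assay likewise gives only a limit, > 1 mg/kg. The step from compound 1 to compound 3 is therefore a step that the two limits leave unreadable from compound 1 to compound 3, a consequence of the limit of > 1 mg/kg in this assay, at which 2 of the 3 values shown sit.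

Compound 2 `Cc1cc(C)c(NC(=O)N(Cc2cccc(-c3cc[nH]n3)c2)C2CCCCCC2)c(C)c1` carries the same urea and cycloheptyl pieces on a second core; the difference between the two cores is not broken down here. Within the data shown here, compound 2 in this assay gives 0.097 mg/kg, the only number in the set.

Compound 4 `Cc1cc(C)c(NC(=O)N(Cc2cccc(-c3cn[nH]c3)c2)C2CCCCCC2)c(C)c1` is the not yet measured partner of compound 2, with the change (1H-pyrazol-4-yl in place of 1H-pyrazol-3-yl on an aromatic carbon). This is the same kind of change as that from compound 1 to compound 3, but the place differs: para to a large group in the first pair, meta to a large group in the second, so the two are not the same. With the earlier step unreadable, the expected step from compound 2 to compound 4 is a 3.1-fold higher number from compound 2 to compound 4 (0.49 log units; beyond the scatter), an estimate resting only on compound 2 at 0.097 mg/kg and on the unreadable step that the two limits leave unreadable from compound 1 to compound 3, with wide uncertainty. The estimate for compound 4 in this assay is 0.3 mg/kg, between 0.08 mg/kg and 1.5 mg/kg.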

Compound 4, dose for half-maximal effect: 0.19 mg/kg
The estimate for compound 4 lay 1.6-fold (0.20 log units) above the measured number; the measured number falls inside the stated range.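

In this assay, 1H-pyrazol-4-yl in place of 1H-pyrazol-3-yl, meta to a large group, gives a 2.0-fold higher number from compound 2 to compound 4 (0.29 log units; within the scatter), so on this core the readings for the two attachments of the pyrazole cannot be told apart. The same change on the core of compound 1 cannot be read, because compound 1 and compound 3 both give a limit and not a number: the limit of > 1 mg/kg in this assay, at which 2 of the 4 values shown sit. The series therefore holds a single readable pair, which shows what the change does on the core of compound 2 but does not show whether the step carries over to the core of compound 1 with the same size, or at all.

Still open, going by these compounds, is the size of the step on the core of compound 1, which would need numbers for both partners. Also open, on these data alone, is how the core of compound 2 responds when a group other than pyrazole stands in the same place, such as a carboxylic acid or a primary amine.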